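A few compounds are considered here, and "the series" means these few. Any claim that something is new, unique, unknown or untested is made for them only; others in the source may bear on it.

Compound 1 `Cc1cc(C)n2nc(SCc3nnc(SCc4coc5ccccc5c4=O)n3N)nc2n1` gives 7100 nM in a functional assay on HEp-2 cells (Homo sapiens) for cytotoxicity, read by MTT assay, with a stated time of 72 h; a lower number here means a stronger inhibitor, a higher number a weaker inhibitor. Compound 2 `Cc1cc(C)n2nc(SCc3nnc(SCc4coc5ccccc5c4=O)n3-c3ccccc3)nc2n1` gives 22100 nM in this assay, the higher of the two numbers; the step from compound 1 to compound 2, phenyl in place of amino on an aromatic nitrogen, was a 3.1-fold higher number from compound 1 to compound 2 (0.49 log units; beyond the scatter). Compound 3 `Cc1cc(O)cc2oc(=O)cc(CSc3nc4ccccc4[nH]3)c12` reaches > 25000 nM, which is a limit of the assay rather than a number (the limit of > 25000 nM in this assay, at which 1 of the 3 values shown sits). Compound 4 `Cc1cc(C)n2nc(SCc3nnc(SCc4cc(=O)c5ccccc5o4)n3-c3ccccc3)nc2n1` differs from compound 2 by a group of 11 heavy atoms (9 carbon, 2 oxygen; one six-membered aromatic ring of carbon only, one six-membered aromatic ring with 1 hetero atom) in place of a group of 11 heavy atoms (9 carbon, 2 oxygen; one six-membered aromatic ring of carbon only, one six-membered aromatic ring with 1 hetero atom), on a saturated chain carbon bound to a sulfur: the two share the same atoms, joined differently. For the measured compounds named here, the one measured step lies on the aromatic nitrogen, not at this place, and no measured step bears on the rearrangement; the expected shift is therefore none beyond the scatter, a 1.0-fold lower number from compound 2 to compound 4 (0.00 log units; within the scatter). Compound 4 is estimated at 22000 nM, between 8000 nM and 60000 nM.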

Compound 4, half-maximal inhibitory concentration: > 25000 nM
Compound 4 was reported as a limit; the forecaster's own chance of this, stated with the estimate: 40%; at least 1.1-fold (0.05 log units) between middle value and limit.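

For the compounds shown here, the first change at this place, on a saturated chain carbon bound to a sulfur, keeps the same atoms but joins them differently, and in this assay it gives an at least 1.1-fold higher number from compound 2 to compound 4 (0.05 log units; that floor lies within the scatter). The rearrangement therefore brought no lower number, whereas the earlier step showed only a change on the aromatic nitrogen. Compound 4 sits at a limit of the assay, not at a number: the limit of > 25000 nM in this assay, at which 2 of the 4 values shown sit.

As far as these compounds go, how the rearranged group would behave with amino on the aromatic nitrogen remains open. So does whether a carboxylic acid or a pyridine ring at this place would lower the number.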